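Changing the ester group on the shared core

The source may hold more compounds than are shown below. What is called first, only, known or untested is meant among the compounds shown, and "the series" means these compounds.

Values so far in a physicochemical assay for solubility, using the shake flask method, in simulated intestinal fluid, measured as kinetic solubility, with a stated time of 2 h, at 25 degrees C, at pH 6.5 (on this read-out lower numbers stand for lower solubility and higher numbers for higher solubility), are these:
Compound 1 `Cc1nc(C#N)c(N)c2c1C(=O)N(Cc1ccccc1)C2=O` gives < 5000 nM (a limit)
Compound 2 `COC(=O)c1nc(C)c2c(c1N)C(=O)N(Cc1ccccc1)C2=O` gives 7400 nM (a number)

Among the measured compounds shown here, compound 2 at 7400 nM holds the only actual number so far. For the measured compounds named here, the single measured step of an at least 1.4-fold higher number from compound 1 to compound 2 (0.17 log units; that floor lies within the scatter) came with methoxycarbonyl in place of cyano on an aromatic carbon, and it does not touch the group changing now. Going by the values given here, compound 3 `Cc1nc(C(=O)OC2CC2)c(N)c2c1C(=O)N(Cc1ccccc1)C2=O` has cyclopropyl in place of methyl on an oxygen next to a carbonyl group and no measured step covers that change. So in this assay no step beyond the scatter is expected. The estimated step of a 1.2-fold lower number from compound 2 to compound 3 (0.09 log units; within the scatter) reflects this. For compound 3 the estimated value is 6000 nM (expected range 3000 nM to 12000 nM).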

Compound 3, solubility: 202000 nM
Compound 3: the middle estimate sits 34-fold (1.53 log units) below what was measured; measured number outside the range, above it.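

In this assay the position on an oxygen next to a carbonyl group proves sensitive: cyclopropyl in place of methyl there gives a 27-fold higher number from compound 2 to compound 3 (1.44 log units; beyond the scatter) and so moves the read-out well beyond the scatter, which the earlier step's floor did not do. Cyclopropyloxycarbonyl in place of cyano gives an at least 40-fold higher number from compound 1 to compound 3 (1.60 log units; beyond the scatter) as the widest step shown. The size of that second step is only a floor, as compound 1 stands at a limit: the limit of < 5000 nM in this assay, at which 1 of the 3 values shown sits.

The compounds shown leave open whether an ethyl group or a longer chain on this oxygen would give a similar step. They also leave open whether the three-membered ring itself matters, or only the added carbons.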